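A few compounds are considered here, and "the series" means these few. Any claim that something is new, unique, unknown or untested is made for them only; others in the source may bear on it.

Compound 1, `Nc1scc(CN2CCN(c3ccc(Cl)cc3Cl)CC2)c1C(=O)c1ccc(Cl)cc1`, gives 0% in an assay on CHO cells for displacement of a labelled ligand from adenosine receptor A3 (Homo sapiens), read by scintillation counting, with a stated time of 120 min, tested at 10 uM; a lower number here means less inhibition, a higher number more inhibition at the concentration tested (going by the name of the read-out).
Compound 2, `Nc1scc(CN2CCN(c3ccc(C(F)(F)F)cc3)CC2)c1C(=O)c1cccc(C(F)(F)F)c1`, gives 0% in this assay.
Compound 3, `Nc1scc(CN2CCN(c3cccc(F)c3)CC2)c1C(=O)c1cccc(C(F)(F)F)c1`, gives 0% in this assay.

Compound 3 stands level with compound 1 and compound 2 at the digits shown; all three sit at the bottom of the read-out, and none of the gaps between them goes beyond the scatter. Among the measured compounds shown here, the one step between measured compounds that differ in a single place is no change at the digits printed from compound 2 to compound 3 (within the scatter), which exchanged the aryl group on the ring nitrogen and left the read-out unmoved.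

Compound 4 is `Nc1scc(CN2CCN(c3c(F)cccc3F)CC2)c1C(=O)c1cccc(C(F)(F)F)c1`. Its difference from compound 3 is 2,6-difluorophenyl in place of 3-fluorophenyl on an amine nitrogen in a ring. For the measured compounds named here, this is the same kind of exchange as the one from compound 2 to compound 3: another aryl group on the same ring nitrogen, with the remaining structure untouched. Because no change at the digits printed from compound 2 to compound 3 (within the scatter) showed no movement, the expected step of no change at the digits printed from compound 3 to compound 4 (within the scatter) is none beyond the scatter. For compound 4 the estimate in this assay is 0%, with a range from -5% to 10%.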

Compound 4, a percentage reported as inhibition, at one concentration (the size of the read-out at that concentration, not a potency): 0%
For compound 4 middle estimate and measured number coincide at the digits printed; measured number inside the range.
By their numbers in this assay, from the lowest: compounds 1, 2, 3 and 4 (each within the scatter of the next).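

In this assay, putting 2,6-difluorophenyl on the amine nitrogen in the ring gives no change at the digits printed from compound 3 to compound 4 (within the scatter), and set against the 4-(trifluoromethyl)phenyl group it gives no change at the digits printed from compound 2 to compound 4 (within the scatter). The position has now taken a third aryl group, with two fluorines on the ring, and the read-out still sits at the bottom of its range, so neither exchange separates these compounds. No supporting data bear on this flat result.

The compounds shown leave open whether any group on this ring nitrogen would lift the read-out off the bottom at all, for instance a pyridine ring, a benzyl group or a carboxylic acid. Also open, from the compounds shown here alone, is whether a change elsewhere on the shared core, such as an amide in place of the amine, would do so.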